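Swapping chloro for methyl at a limit-bound compound

The source may hold more compounds than are shown below. What is called first, only, known or untested is meant among the compounds shown, and "the series" means these compounds.

Measured in a functional assay on DU-145 cells (Homo sapiens) for inhibition, read by trypan blue exclusion, with a stated time of 96 h; a lower number here means a stronger inhibitor of growth, a higher number a weaker inhibitor of growth:
- compound 1 `Cc1ccc(CS/C(=C/c2ccc(Br)cc2)C(=O)c2ccc(Cl)cc2)cc1`: 10000 nM
- compound 2 `Cc1ccc(CS/C(=C/c2c[nH]c3ccc(Cl)cc23)C(=O)c2ccc(Cl)cc2)cc1`: 1000 nM
- compound 3 `CN(C)c1ccc(/C=C(/SCc2ccc(Cl)cc2)C(=O)c2ccc(Cl)cc2)cc1`: > 100000 nM (a limit)

Compound 3 stands at > 100000 nM, which is a limit of the assay and not a number. Compound 4 `Cc1ccc(CS/C(=C/c2ccc(N(C)C)cc2)C(=O)c2ccc(Cl)cc2)cc1` differs from it by methyl in place of chloro on an aromatic carbon, turning 4-chlorobenzyl into 4-methylbenzyl. For the measured compounds named here, no measured step makes this swap. The only one, a 10-fold lower number from compound 1 to compound 2 (1.00 log units; beyond the scatter), changes a different group and gives no direct size for this change. Going by the values given here, the sole guide is compound 1, which also carries 4-methylbenzyl and gives 10000 nM. A modest move to a lower number is therefore expected, though another limit remains possible. An estimated at least 2.5-fold lower number from compound 3 to compound 4 (0.39 log units; beyond the scatter) is expected in this assay. Compound 4 is expected at 40000 nM, with an estimated range of 5000 nM to 100000 nM.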

Compound 4, concentration for 50% growth inhibition: > 100000 nM
Compound 4: only a limit was reported; the forecaster's own chance of this, stated with the estimate: 45%; middle value at least 2.5-fold (0.39 log units) from the limit.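

In this assay, the change of chloro to methyl cannot be read, because compound 3 and compound 4 both sit at a limit and not at a number: the limit of > 100000 nM in this assay, at which 2 of the 4 values shown sit. With 4-methylbenzyl kept in place, dimethylamino in place of bromo gives an at least 10-fold higher number from compound 1 to compound 4 (1.00 log units; beyond the scatter). The same 4-methylbenzyl with 4-(dimethylamino)phenyl in place of 5-chloro-1H-indol-3-yl gives an at least 100-fold higher number from compound 2 to compound 4 (2.00 log units; beyond the scatter), so 4-methylbenzyl alone does not bring the dimethylamino series to a measurable number.

Going by these compounds, it stays open how chloro and methyl compare on a compound that gives a number. Also open, on these data alone, is whether an unsubstituted amine or a methoxy group in place of dimethylamino would return one.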